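The source may report more compounds than this note shows. Statements on the series, on what has been measured and on what is new or still open speak of the compounds shown alone.

Compound 2 `COc1cc(-c2nn(-c3cccc(NC(=O)Nc4ccc(Cl)c(C(F)(F)F)c4)c3)cc2-c2ccncc2)ccc1Cl` and compound 1 `COc1cc(-c2nn(-c3cccc(NC(=O)Nc4ccc(Cl)c(Cl)c4)c3)cc2-c2ccncc2)ccc1Cl` share one core and differ only in a single substituent on the outer aromatic ring. In a functional assay on HCT-116 cells (Homo sapiens) for inhibition, read by sulforhodamine B assay, with a stated time of 48 h (a lower number here means a stronger inhibitor of growth, a higher number a weaker inhibitor of growth), compound 1 gives 1210 nM, and compound 2 gives 1170 nM. The two numbers sit side by side: a 1.0-fold lower number from compound 1 to compound 2 (0.01 log units; within the scatter). Compound 2 therefore has the lower of the two numbers, but the gap to compound 1 falls inside the scatter, so neither can be called the stronger inhibitor.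

Compound 3 `COc1cc(-c2nn(-c3cccc(NC(=O)c4ccccc4)c3)cc2-c2ccncc2)ccc1Cl` is not yet measured. It differs from compound 2 in this way: phenyl in place of (4-chloro-3-(trifluoromethyl)phenyl)amino on a carbonyl carbon. The urea is thereby shortened to a benzamide, and the substituted aromatic ring together with its amide hydrogen is gone.

For the measured compounds named here, the one measured step, from compound 1 to compound 2, exchanges substituents on the ring that compound 3 no longer carries, so it does not speak to this change. The expectation rests only on the size of the alteration, which is large. Compound 3 is estimated to give 5000 nM, within a range of 1500 nM to 20000 nM; this would be a step of a 4.3-fold higher number from compound 2 to compound 3 (0.63 log units; beyond the scatter) towards weaker inhibition.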

Compound 3, concentration for 50% growth inhibition: 500 nM
Compound 3: middle estimate off by 10-fold (1.00 log units), on the high side; measured number below the stated range.
By their numbers in this assay, from the lowest: compound 3; then compounds 2 and 1 (each within the scatter of the next).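

Compound 1 and compound 2 showed only that exchanging one substituent on the outer ring left the number unchanged within the scatter; compound 3 shows that in this assay the whole (substituted phenyl)amino part on the carbonyl carbon can be replaced without a loss. Phenyl in place of (4-chloro-3-(trifluoromethyl)phenyl)amino gives a 2.3-fold lower number from compound 2 to compound 3 (0.37 log units; beyond the scatter) and phenyl in place of (3,4-dichlorophenyl)amino gives a 2.4-fold lower number from compound 1 to compound 3 (0.38 log units; beyond the scatter) in two modest steps towards stronger inhibition, which makes compound 3 the strongest inhibitor of these three even though it has lost the amide hydrogen, the nitrogen and both ring substituents of the urea. No measurement shown here accounts for this gain.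

Each step removes the nitrogen and the ring substituents together, so the compounds shown cannot tell which of these losses matters for the gain. From the compounds shown here alone, a plain phenylamino group on the carbonyl carbon, or a chloro or trifluoromethyl group on the phenyl ring of compound 3, would separate these parts, and how an amine or a carboxylic acid on that ring would behave remains open.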